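Replacing the acetyl of compound 2: cytotoxicity notes

The source may hold more compounds than are shown below. What is called first, only, known or untested is meant among the compounds shown, and "the series" means these compounds.

In an ADME assay on MDBK cells (Bos taurus) for cytotoxicity, read by MTT assay, with a stated time of 96 h (on this read-out lower numbers stand for higher toxicity in this test and higher numbers for lower toxicity in this test), compound 2 (`CC(=O)c1ccc2[nH]c(-c3ccc(C(F)(F)F)cc3)nc2c1`) has no number, only a limit of > 100000 nM. Compound 1 (`CC(=O)c1ccc2[nH]c(-c3ccc(Cl)cc3)nc2c1`) likewise reaches only a limit of > 100000 nM. Compound 3 (`COc1ccc(-c2nc3cc(/C(C)=N/O)ccc3[nH]2)c(OC)c1OC`) also gives only a limit of > 100000 nM. Going by the values given here, the series so far therefore stands as follows: the limit of > 100000 nM in this assay, at which 3 of the 3 values shown sit.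

Compound 4 (`C/C(=N\NC(N)=O)c1ccc2[nH]c(-c3ccc(C(F)(F)F)cc3)nc2c1`) differs from compound 2 in one place, on an aromatic carbon: a group of 7 heavy atoms (3 carbon, 3 nitrogen, 1 oxygen; no ring) in place of a group of 3 heavy atoms (2 carbon, 1 oxygen; no ring), on an aromatic carbon. Among the compounds with values here, the only measured step, a step that the two limits leave unreadable from compound 1 to compound 2, concerns trifluoromethyl in place of chloro, a different change, and has no readable size. Within the data shown here, no measured step therefore sizes this replacement, and no direction can be read from the data. The expectation rests on compound 2 and its limit of > 100000 nM. In this assay, the expected change is a number no higher from compound 2 to compound 4 (the limit leaves the size open), estimated as none beyond the scatter, with some allowance towards lower numbers. For compound 4, the estimated value is 100000 nM, with an expected range of 40000 nM to 100000 nM, and a report of only a limit is likely.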

Compound 4, half-maximal cytotoxic concentration: > 100000 nM
Compound 4 ended at the assay's limit (the forecaster's own chance of this, stated with the estimate: 70%); the middle value sits exactly at the limit.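

In this assay compound 4 gives only a limit, > 100000 nM, and compound 2 also has only a limit, so no step can be read between compound 2 and compound 4. The compounds shown leave open whether any change to the series gives a readable number, with every result so far at one place: the limit of > 100000 nM in this assay, at which 4 of the 4 values shown sit.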